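The source may hold more compounds than are shown below. What is called first, only, known or untested is meant among the compounds shown, and "the series" means these compounds.

Measured in a functional assay on MCF7 cells (Homo sapiens) for antiproliferative activity, read by MTT assay, with a stated time of 72 h; a lower number here means a stronger inhibitor, a higher number a weaker inhibitor:
- Compound 1 `COc1cc(-n2ncnc2-c2ccc(OC(F)(F)F)cc2)cc(OC)c1OC`: > 10000 nM, a limit
- Compound 2 `COc1cc(-n2ncnc2-c2ccc(Cl)c(Cl)c2)cc(OC)c1OC`: > 10000 nM, a limit

Neither entry is a true number. Each says only that half-maximal inhibition was not reached within the tested range. On these data alone, compound 2 gives > 10000 nM, which is a limit of the assay, so its real position is unknown. Among the measured compounds shown here, compound 2 and compound 1 share that ceiling, (the limit of > 10000 nM in this assay, at which 2 of the 2 values shown sit), and so no measured step exists to show how much a change of this kind can do.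

Compound 3 `COc1cc(-n2ncnc2-c2ccc(SC)cc2)cc(OC)c1OC` keeps the shared core and carries 4-(methylsulfanyl)phenyl in place of 3,4-dichlorophenyl on an aromatic carbon.

With both measured compounds sitting at the limit of > 10000 nM in this assay, at which 2 of the 2 values shown sit, the expectation is cautious: little visible change in this assay, or a modest move toward stronger inhibition. The expected size of this move, an at least 1.2-fold lower number from compound 2 to compound 3 (0.09 log units; that floor lies within the scatter), is only an estimate, and another limit would be no surprise. For compound 3 the estimated value is 8000 nM, with an expected range of 500 nM to 30000 nM.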

Compound 3, half-maximal inhibitory concentration: 390 nM
The estimate for compound 3 lay 21-fold (1.31 log units) above the measured number, outside the stated range (below it).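

In this assay, among the compounds shown here, compound 3 gives 390 nM, the only real number among the three compounds, which shows that a phenyl group on this aromatic carbon of the five-membered ring can give measurable activity in cells. The identity of that phenyl group clearly matters: 4-(methylsulfanyl)phenyl in place of 3,4-dichlorophenyl gives an at least 25-fold lower number from compound 2 to compound 3 (1.40 log units; beyond the scatter), and methylsulfanyl in place of trifluoromethoxy gives an at least 25-fold lower number from compound 1 to compound 3 (1.40 log units; beyond the scatter). Both steps are minimum sizes rather than exact ones, because their starting compounds have no true value in this assay: the limit of > 10000 nM in this assay, at which 2 of the 3 values shown sit.

For the compounds shown here, with only one real value, no trend across groups can be drawn, and it stays open whether the sulfur atom itself is needed or whether methoxy, with oxygen in its place, would serve as well. On these data alone, it is also open how this position would respond to a longer chain such as ethylsulfanyl, to an amine such as dimethylamino, or to a carboxylic acid.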